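Quinoline series: amine tail change at the solubilizing chain

The source may report more compounds than this note shows. Statements on the series, on what has been measured and on what is new or still open speak of the compounds shown alone.

Measured compounds:
Compound 1 `COc1cc2c(Oc3ccc(NC(=O)c4nn(-c5ccccc5C)c(=O)cc4C)cc3F)ccnc2cc1OCCCN1CCCCC1` — 2810 nM
Compound 2 `COc1cc2c(Oc3ccc(NC(=O)c4nn(-c5ccccc5OC(F)(F)F)c(=O)cc4C)cc3F)ccnc2cc1OCCCN1CCCC1` — 180 nM

In a functional assay on HT-29 cells (Homo sapiens) for inhibition, read by MTT assay, with a stated time of 72 h (on this read-out higher numbers stand for weaker inhibition and lower numbers for stronger inhibition), compound 1 gives 2810 nM, whereas compound 2 gives 180 nM. Among the compounds with values here, compound 2 thus stands at the lowest number of the two measured so far, and its gap to compound 1 lies beyond the scatter. Within the data shown here, compound 1 and compound 2 differ in two places at once, so no single-point step between them can be read; only the two values themselves are known.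

Compound 3 `COc1cc2c(Oc3ccc(NC(=O)c4nn(-c5ccccc5OC(F)(F)F)c(=O)cc4C)cc3F)ccnc2cc1OCCCN1CCCCC1` is not yet measured. It differs from compound 2 in one place only: piperidin-1-yl in place of pyrrolidin-1-yl on a saturated chain carbon, three bonds along the chain from an oxygen on an aromatic ring. The aryl substituent that distinguishes compound 2 from compound 1 is kept.

Among the measured compounds shown here, no step of this kind between measured compounds is available. The expectation for compound 3 is a step of a 1.1-fold higher number from compound 2 to compound 3 (0.05 log units; within the scatter) from compound 2, that is, no change beyond the scatter in this assay. Compound 3 is therefore estimated at 200 nM, within a range of 80 nM to 500 nM.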

Compound 3, half-maximal inhibitory concentration: 190 nM
For compound 3 the middle estimate is 1.1-fold (0.02 log units) above the measured one, and the stated range covers the measured number.
By their numbers in this assay, from the lowest: compounds 2 and 3 (each within the scatter of the next); then compound 1.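

In this assay, exchanging the amine at the end of the chain gives a 1.1-fold higher number from compound 2 to compound 3 (0.02 log units; within the scatter), so with trifluoromethoxy kept on the aryl ring, these data do not separate piperidin-1-yl from pyrrolidin-1-yl at this saturated chain carbon. Compound 3 also provides the single-place comparison that compound 1 and compound 2 could not: with the 3-(piperidin-1-yl)propyl tail held constant, trifluoromethoxy in place of methyl on an aromatic carbon gives a 15-fold lower number from compound 1 to compound 3 (1.17 log units; beyond the scatter) in this assay, a large step set against a tail exchange that stays within the scatter. No measurement shown here bears on the reason for either step.

From the compounds shown here alone, it remains open whether the same insensitivity extends to other terminal amines, such as morpholine or 4-methylpiperazine, or to a shorter or longer chain than the propyl linker in compound 2 and compound 3. Going by these compounds, the trifluoromethoxy-for-methyl step also rests on a single pair, so it is unknown how other groups at that aromatic carbon, such as chlorine or methoxy, would compare, or whether the step has the same size with the pyrrolidin-1-yl tail.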